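Moving the Pyridine Nitrogen and Cytotoxicity in MT2 Cells

A few compounds are considered here, and "the series" means these few. Any claim that something is new, unique, unknown or untested is made for them only; others in the source may bear on it.

Going by the values given here, compound 1 `Fc1cccc(F)c1Cc1cnc(Nc2ccc(-c3ccncc3)c(Cl)c2)o1` is the only member of this small set with a definite number in an ADME assay on MT2 cells (Homo sapiens) for cytotoxicity, read by MTT assay; on this read-out higher numbers stand for lower toxicity in this test and lower numbers for higher toxicity in this test: there compound 1 gives 9300 nM. The two other compounds reach only the edge of the assay. Compound 2 `CSCc1ccc(Nc2ncc(Cc3c(F)cccc3F)o2)cc1` stops at the limit of > 100000 nM in this assay, so its toxicity is too weak to be pinned down. Compound 3 `Clc1cccc(Cl)c1Cc1nnc(Nc2ccc(COCc3ccsc3)cc2)o1` likewise stops at the limit of > 100000 nM in this assay. Among the compounds with values here, in short, (the limit of > 100000 nM in this assay, at which 2 of the 3 values shown sit), and compound 1 stands apart as the one compound with a measurable half-maximal cytotoxic concentration.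

Compound 4 `Fc1cccc(F)c1Cc1cnc(Nc2ccc(-c3cccnc3)c(Cl)c2)o1` has not yet been tested. It keeps every atom of compound 1 and differs only in how they are joined: pyridin-3-yl in place of pyridin-4-yl on an aromatic carbon. Within the data shown here, no pair among the measured compounds shows a step of this kind, so no direction can be read from them. Swapping pyridin-4-yl for pyridin-3-yl changes little of the molecule, and in this assay the step is expected to stay within the usual scatter: a 1.1-fold higher number from compound 1 to compound 4 (0.03 log units; within the scatter). Compound 4 is therefore estimated to give 10000 nM, with a likely range from 4000 nM to 30000 nM.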

Compound 4, half-maximal cytotoxic concentration: 8900 nM
For compound 4 the middle estimate is 1.1-fold (0.05 log units) above the measured one, within the range that was stated.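

Going by these compounds alone, the swap of pyridin-3-yl for pyridin-4-yl on this aromatic carbon gives the first step in this assay that can be read directly, and it comes to a 1.0-fold lower number from compound 1 to compound 4 (0.02 log units; within the scatter) as the whole effect of moving the ring nitrogen. At this position, ortho to a chloro group and para to a large group, the two placements of the nitrogen cannot be told apart in this test, even though the atoms are joined differently. Within the data shown here, no earlier pair differed in one place only, so the earlier compounds could say nothing about any single change, and this reading covers just this one swap on this one core.

Going by these compounds, whether the pyridine ring itself matters remains open, as a plain phenyl ring, an amine or a carboxylic acid on this same carbon could shift the number in either direction or leave it where it is. Compound 2 and compound 3 still offer only a limit rather than a number, so neither can yet anchor a comparison in this set: the limit of > 100000 nM in this assay, at which 2 of the 4 values shown sit.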